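The source may report more compounds than this note shows. Statements on the series, on what has been measured and on what is new or still open speak of the compounds shown alone.

Measured so far:
compound 1, `Nc1nc(-c2ccco2)nc2sc(CNC3CCCCC3)cc12`: 2480 nM
compound 2, `Nc1nc(-c2ccco2)nc2sc(CN3CCCC3)cc12`: 6430 nM

Compound 2 holds the highest of the two numbers measured in an assay on CHO-K1 cells for antagonist activity at adenosine receptor A1 (Homo sapiens), read by a beta-galactosidase reporter, with stated times of 15 min and 6 h; a lower number here means a stronger inhibitor, a higher number a weaker inhibitor; its nearest neighbour is compound 1, and the step of a 2.6-fold higher number from compound 1 to compound 2 (0.41 log units; beyond the scatter) is modest but beyond the scatter. Compound 3, `Nc1nc(-c2ccco2)nc2sc(CN3CC=CCC3)cc12`, differs from compound 2 in one place: a group of 6 heavy atoms (5 carbon, 1 nitrogen; one six-membered non-aromatic ring with 1 hetero atom) in place of a group of 5 heavy atoms (4 carbon, 1 nitrogen; one five-membered non-aromatic ring with 1 hetero atom), on a saturated chain carbon bound to an aromatic carbon. Among the compounds with values here, no measured pair shows this exact exchange, so the only step that bears on it indirectly is a 2.6-fold higher number from compound 1 to compound 2 (0.41 log units; beyond the scatter), where the move from cyclohexylamino to pyrrolidin-1-yl gave a higher number. Compound 3 moves away from pyrrolidin-1-yl again, toward a larger ring on the same saturated chain carbon, so a modest step back toward the number of compound 1 is plausible, though this rests on a single step. For compound 3 the expected change is a 1.6-fold lower number from compound 2 to compound 3 (0.21 log units; within the scatter). Compound 3 is estimated at 4000 nM, with a range from 1500 nM to 11000 nM.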

Compound 3, inhibition constant: 150 nM
Compound 3: middle estimate off by 27-fold (1.43 log units), on the high side; the whole stated range lies above it.
By their numbers in this assay, from the lowest: compound 3; then compound 1; then compound 2.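

In this assay, the group on the saturated chain carbon bound to an aromatic carbon can shift the number far more than the first step indicated (a 43-fold lower number from compound 2 to compound 3 (1.63 log units; beyond the scatter)), with the six-membered non-aromatic ring carrying 1 double bond in place of pyrrolidin-1-yl. The change does not merely return the value toward that of compound 1 but passes it (a 17-fold lower number from compound 1 to compound 3 (1.22 log units; beyond the scatter)), leaving compound 3 lowest of the three, with both steps beyond the scatter. No evidence at hand accounts for this gain.

The compounds shown do not separate ring size from the double bond; piperidin-1-yl, the saturated six-membered ring, is the direct comparison with compound 3. Also open, from the compounds shown here alone, is how morpholin-4-yl, with a ring oxygen, or a longer chain in place of the saturated chain carbon compares.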